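This account rests on a few compounds, and the source may have more. Where it says the series, first, only, none or still open, it means among the compounds named here.

Compound 1 `COc1ccc(C)cc1N1C(=O)CSC1c1cccc(C(=O)NCCCCc2ccccc2)c1` was tested in a functional assay on HOS-TE85 cells (Homo sapiens) for inhibition, read by CCK-8 assay, with a stated time of 72 h (a higher number here means a weaker inhibitor, a lower number a stronger inhibitor), where compound 1 gives 300 nM. Compound 2 `Cc1ccnc(N2C(=O)CS[C@@H]2c2cccc(C(=O)NCCCCn3cccn3)c2)c1` gives 21.9 nM in this assay, a lower number than that of compound 1 by a margin beyond the usual scatter, so of the two numbers in hand compound 1 holds the higher one. Compound 3 `COc1ccccc1N1C(=O)CSC1c1cccc(C(=O)NCCCCN2C(=O)C=CC2=O)c1` reaches only the limit of this assay, reported as > 1000 nM, so no number is known for it. Compound 4 `CC(F)(F)c1cccc(N2C(=O)CSC2c2cccc(C(=O)NCCCCc3ccccc3)c2)c1` has not yet been measured. It differs from compound 1 in one place: a group of 10 heavy atoms (8 carbon, 2 fluorine; one six-membered aromatic ring of carbon only) in place of a group of 9 heavy atoms (8 carbon, 1 oxygen; one six-membered aromatic ring of carbon only), on an amide-type nitrogen in a ring. Going by the values given here, no two measured compounds differ from each other in only one place, so no measured step gives a direct guide to the size of this change. The change is expected to shift the number only modestly, and the step of a 1.3-fold higher number from compound 1 to compound 4 (0.12 log units; within the scatter) is estimated to sit near the edge of the usual scatter. Compound 4 is expected to give about 400 nM in this assay, with a likely range from 120 nM to 1300 nM.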

Compound 4, half-maximal inhibitory concentration: 29.1 nM
The estimate for compound 4 lay 14-fold (1.14 log units) above the measured number; measured number below the stated range.
By their numbers in this assay, from the lowest: compounds 2 and 4 (each within the scatter of the next); then compound 1. At a limit, above all of these: compound 3.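

In this assay the swap of the 2-methoxy-5-methylphenyl group on the amide-type nitrogen in a ring for the fluorine-bearing aromatic group gives a 10-fold lower number from compound 1 to compound 4 (1.01 log units; beyond the scatter) with the rest of the molecule unchanged. Going by these compounds alone, this is the first measured step at this position, and it shows that the aromatic group on this nitrogen alone can move the number well beyond the usual scatter. Nothing measured here bears on the reason for the drop.

From the compounds shown here alone, the change removes the methoxy and methyl groups and brings in fluorine all at once, so it remains open which part of it matters, and a plain phenyl or a phenyl carrying a nitrile could help to separate these parts. Going by these compounds, it also remains open whether the same swap has a similar effect alongside the different chains of compound 2 and compound 3.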